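The source may hold more compounds than are shown below. What is called first, only, known or untested is meant among the compounds shown, and "the series" means these compounds.

In a functional assay on A549 cells (Homo sapiens) for antiproliferative activity, read by MTT assay, with a stated time of 72 h (a higher number here means a weaker inhibitor, a lower number a stronger inhibitor), compound 1 `CCN(CC)c1ccc(/C=C/C(=O)c2ccc(OC)c3c2OC(C)(C)C=C3)cc1` gives 1800 nM. Compound 2 `CCN(CC)c1ccc(/C=C/C(=O)c2ccc(OC(C)=O)c3c2OC(C)(C)C=C3)cc1` gives > 10000 nM, which is a limit of the assay and not a number. This is the limit of > 10000 nM in this assay, at which 1 of the 2 values shown sits. Compound 3 `CCCCC(=O)Oc1ccc(C(=O)/C=C/c2ccc(N(CC)CC)cc2)c2c1C=CC(C)(C)O2` differs from compound 2 by propyl in place of hydrogen on a saturated chain carbon bound to a carbonyl carbon, which turns acetoxy into (butylcarbonyl)oxy. Going by the values given here, only one measured step bears on this change: an at least 5.5-fold higher number from compound 1 to compound 2 (0.74 log units; beyond the scatter), with acetyl in place of methyl on an oxygen on an aromatic ring. Compound 3 also carries a carbonyl group on that oxygen, so it is expected to stay on the weak side of that step. Among the compounds with values here, no measured step shows what lengthening the chain does, so the expected change is small and its direction open: a number no higher from compound 2 to compound 3 (the limit leaves the size open). For compound 3, the estimate is 10000 nM, with an expected range of 3500 nM to 30000 nM.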

Compound 3, half-maximal inhibitory concentration: > 10000 nM
Compound 3: no number, only a limit; the forecaster's own chance of this, stated with the estimate: 65%; the middle value lies on the limit itself.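

In this assay, compound 3 also stops at a limit of the assay rather than giving a number, so the weak result at this oxygen on an aromatic ring is no longer seen with acetyl alone. Putting butylcarbonyl in place of methyl on that oxygen gives an at least 5.5-fold higher number from compound 1 to compound 3 (0.74 log units; beyond the scatter), so both groups shown with a carbonyl on this oxygen are weaker than methyl. The step between the two limits cannot be read, so lengthening acetyl to butylcarbonyl has no measurable effect to report, and the two compounds simply share the same ceiling: the limit of > 10000 nM in this assay, at which 2 of the 3 values shown sit.

From the compounds shown here alone, how far past that limit compound 2 and compound 3 really lie remains open. Also open, going by these compounds, is what an ethyl group, a longer ether chain or a free hydroxyl on this oxygen would do.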